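Trimming the pyrazole from compound 1: working notes

A few compounds are considered here, and "the series" means these few. Any claim that something is new, unique, unknown or untested is made for them only; others in the source may bear on it.

Measured so far:
compound 1 `C[C@@H]1CCCN1c1c(C#N)c2c(N)nc(Nc3cn[nH]c3)nc2n1C`: 6 nM
compound 2 `Cc1cn(C)nc1Nc1cc2c(c(N)n1)c(C#N)c(N1CCC[C@H]1C)n2C`: 1290 nM
compound 3 `Cc1c(Nc2nc(N)c3c(C#N)c(N4CCC[C@H]4C)n(C)c3n2)cnn1CC1(O)COC1`: 10 nM

In an assay on isolated protein for inhibition of Leucine-rich repeat serine/threonine-protein kinase 2 variant G2019S (Homo sapiens), read by TR-FRET and LanthaScreen, with stated times of 50 min and 30 min, in the presence of a further agent that is not named here (on this read-out higher numbers stand for weaker inhibition and lower numbers for stronger inhibition), compound 1 gives 6 nM, the lowest of the three numbers. Compound 3 gives 10 nM, which lies within the scatter of compound 1, so the two cannot be ordered. Compound 2 gives 1290 nM, a number far beyond the scatter above compound 1. Among the compounds with values here, none of the three measured compounds differ from one another in a single place, so no measured step is available within this set.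

Compound 4 `C[C@@H]1CCCN1c1c(C#N)c2c(N)nc(N)nc2n1C` differs from compound 1 by hydrogen in place of 1H-pyrazol-4-yl on a nitrogen on an aromatic ring. Within the data shown here, no measured pair covers this change. What the set does show is that the group on this nitrogen matters: compound 1 and compound 2 carry different groups there and their numbers are far apart, though they also differ elsewhere. Removing the group altogether is expected to weaken inhibition strongly, and the step from compound 1 to compound 4 is estimated as a 250-fold higher number from compound 1 to compound 4 (2.40 log units; beyond the scatter). Compound 4 is accordingly expected at about 1500 nM, with a range from 200 nM to 10000 nM.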

Compound 4, half-maximal inhibitory concentration: 217 nM
For compound 4 the middle estimate is 6.9-fold (0.84 log units) above the measured one; low and high end bracket the measured number.
By their numbers in this assay, from the lowest: compounds 1 and 3 (each within the scatter of the next); then compound 4; then compound 2.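

Within the data shown here, the first single-place step is now in hand: in this assay, hydrogen in place of 1H-pyrazol-4-yl on a nitrogen on an aromatic ring gives a 36-fold higher number from compound 1 to compound 4 (1.56 log units; beyond the scatter) and lies beyond the scatter. The group on this nitrogen therefore accounts for a large part of the inhibition seen with compound 1, and this no longer rests on the comparison of compounds that also differ elsewhere. Inhibition does not disappear with the 5 heavy atoms gone, however, since the amino compound 4 still gives 217 nM on the unchanged remainder of the structure, and nothing measured here gives a reason for the size of the step.

As far as these compounds go, how a methyl group, an acetyl group or a phenyl ring on this nitrogen would stand relative to hydrogen and 1H-pyrazol-4-yl remains open, so it cannot yet be said whether the step belongs to the pyrazole ring itself or to any group at this place. Equally open, from the compounds shown here alone, is whether removal would cost as much starting from compound 3, which carries a larger group on this nitrogen.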